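Working notes on the series: methoxy to chloro swap

This account rests on a few compounds, and the source may have more. Where it says the series, first, only, none or still open, it means among the compounds named here.

Compound 1 `O=C(CCCCC1CCSS1)NCc1cn(CCCOc2ccc3cc(C(=O)O)c(=O)oc3c2)nn1` in a functional assay on PC-12 cells (Rattus norvegicus) for cytotoxicity, read by MTT assay, with stated times of 3 h and 2 h, tested at 5 uM (a lower number here means a weaker effect, a higher number a stronger effect of the compound at the concentration tested), gives 57%. Compound 2 `COc1ccc(-c2cc3ccc(OCCCn4cc(CNC(=O)CCCCC5CCSS5)nn4)cc3oc2=O)cc1` in this assay gives 52.8%. The only step measured so far, a number 4.2 percentage points lower from compound 1 to compound 2 (within the scatter), separates these two by less than the scatter, so compound 2 stands level with compound 1 on the numbers shown, and neither can be called the stronger of the pair.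

Compound 3 `O=C(CCCCC1CCSS1)NCc1cn(CCCOc2ccc3cc(-c4ccc(Cl)cc4)c(=O)oc3c2)nn1` differs from compound 2 by chloro in place of methoxy on an aromatic carbon. Going by the values given here, the one measured step, which changed the group at the same region of the shared core, was a number 4.2 percentage points lower from compound 1 to compound 2 (within the scatter) and stayed within the scatter. Among the compounds with values here, no measured pair isolates chloro against methoxy. Going from methoxy to chloro is therefore expected to give a number 0.2 percentage points higher from compound 2 to compound 3 (within the scatter), a step not beyond the scatter in either direction. Compound 3 is estimated at 53% in this assay, with a range from 42% to 64%.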

Compound 3, a percentage reported as activity, at one concentration (the size of the read-out at that concentration, not a potency): 60.6%
Estimate against measurement, compound 3: 7.6 percentage points below; the range from low to high includes it.
By their numbers in this assay, from the lowest: compounds 2, 1 and 3 (each within the scatter of the next).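

A measured pair now isolates chloro against methoxy on an aromatic carbon para to a large group, and in this assay that change reads a number 7.8 percentage points higher from compound 2 to compound 3 (within the scatter). Putting 4-chlorophenyl in place of carboxy reads a number 3.6 percentage points higher from compound 1 to compound 3 (within the scatter), so, with the earlier step, carboxy, 4-methoxyphenyl and 4-chlorophenyl all stand level in this region of the shared core, and neither change separates from the scatter. No evidence on hand bears on these numbers.

On these data alone, whether this position can give a step beyond the scatter remains open: an amine or a nitrile in place of chloro on the same aromatic carbon would test that. As far as these compounds go, since the read-out comes from one concentration, the potency of all three compounds also remains open.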